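Removing the (4-Bromophenyl)carbonyl Group from Compound 2

The source may hold more compounds than are shown below. What is called first, only, known or untested is meant among the compounds shown, and "the series" means these compounds.

For the measured compounds named here, compound 2 `O=C(OC1(C(=O)Nc2ccc([N+](=O)[O-])cc2)CCCCC1)c1ccc(Br)cc1` gives 237 nM in a functional assay on MCF7 cells (Homo sapiens) for inhibition, read by MTT assay, with a stated time of 72 h (a lower number here means a stronger inhibitor, a higher number a weaker inhibitor), the highest of the three numbers measured so far. Compound 1 `COc1ccc(C(=O)OC2(C(=O)Nc3ccc([N+](=O)[O-])cc3)CCCCC2)cc1` gives 41.2 nM in this assay, and compound 3 `O=C(OC1(C(=O)Nc2ccc([N+](=O)[O-])cc2)CCCCC1)C(O)c1ccccc1` gives 5.01 nM. The step of a 5.8-fold higher number from compound 1 to compound 2 (0.76 log units; beyond the scatter) is modest, the step of an 8.2-fold lower number from compound 1 to compound 3 (0.92 log units; beyond the scatter) is modest as well, and the step of a 47-fold lower number from compound 2 to compound 3 (1.67 log units; beyond the scatter) is large; all three lie beyond the scatter.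

Compound 4 `O=C(Nc1ccc([N+](=O)[O-])cc1)C1(O)CCCCC1` differs from compound 2 by hydrogen in place of (4-bromophenyl)carbonyl on an oxygen on a saturated carbon. Going by the values given here, no measured step bears directly on this change: each of the three exchanges keeps the ester and alters only the group on its carbonyl carbon or on its aromatic ring, whereas here the whole ester leaves and a free hydroxyl remains. What the measured steps do show is that the number responds strongly to what sits on this oxygen, since a 47-fold lower number from compound 2 to compound 3 (1.67 log units; beyond the scatter) and a 5.8-fold higher number from compound 1 to compound 2 (0.76 log units; beyond the scatter) were both beyond the scatter. With the group removed entirely, compound 4 is expected to give a higher number than any of the three, with wide uncertainty. The expected step is a 13-fold higher number from compound 2 to compound 4 (1.10 log units; beyond the scatter). Compound 4 is estimated at 3000 nM in this assay, with a range from 400 nM to 30000 nM.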

Compound 4, half-maximal inhibitory concentration: 664 nM
Estimate against measurement, compound 4: 4.5-fold (0.65 log units) above; measured number inside the range.
By their numbers in this assay, from the lowest: compound 3; then compound 1; then compound 2; then compound 4.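

Losing the entire (4-bromophenyl)carbonyl group, with its aromatic ring and carbonyl, costs less in this assay than might be supposed from the exchanges among the esters: the change from ester to free hydroxyl is a modest step (a 2.8-fold higher number from compound 2 to compound 4 (0.45 log units; beyond the scatter)), while exchanging the group on the carbonyl carbon is a large one (a 47-fold lower number from compound 2 to compound 3 (1.67 log units; beyond the scatter)). The position therefore tolerates having no acyl group at all, since compound 4 still gives a measurable number (664 nM), yet the step is beyond the scatter, so the 4-bromophenyl ester keeps a real advantage over the free hydroxyl, and the other two esters also show lower numbers than compound 4. Nothing at hand explains why removing so large a group changes the number so little.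

The compounds shown leave open how small a group on this oxygen can be and still lower the number, for instance an acetyl group or a methyl ether. They also leave open whether an amine in place of the hydroxyl of compound 4 would give a number nearer to those of the esters.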